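Two Fluorines in Place of Two Methyls

This account rests on a few compounds, and the source may have more. Where it says the series, first, only, none or still open, it means among the compounds named here.

Compound 2 `Cc1cc(NCc2ccccn2)n2ncc(-c3c(C)cccc3C)c2n1` has been tested in a physicochemical assay for solubility, read by HPLC, using the shake flask method, measured as kinetic solubility, with a stated time of 2 h, at pH 7.4; a higher number here means a more soluble compound, a lower number a less soluble compound. In this assay compound 2 gives < 5000 nM, which is a limit of the assay rather than a number. Compound 1 `Cc1cc(NCc2ccccn2)n2ncc(-c3cccc(Cl)c3)c2n1` shares the same core and differs only in the aromatic group attached to it. In this assay compound 1 gives < 5000 nM, again a limit rather than a number. The step that the two limits leave unreadable from compound 1 to compound 2 therefore cannot be read. Both values sit at the limit of < 5000 nM in this assay, at which 2 of the 2 values shown sit. Compound 3 `Cc1cc(NCc2ccccn2)n2ncc(-c3ccc(F)cc3F)c2n1` has not yet been measured. The change from compound 2 to compound 3 is 2,4-difluorophenyl in place of 2,6-dimethylphenyl on an aromatic carbon. Among the compounds with values here, no measured step bears on this change, since the single step available is unreadable, so the data give no direction. Compound 3 is expected to stay near the limit, the expected step being a step that the limit leaves unreadable from compound 2 to compound 3. The estimate for compound 3 is 3000 nM, within a range from 500 nM to 12000 nM.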

Compound 3, solubility: < 5000 nM
Compound 3 was reported as a limit (the forecaster's own chance of this, stated with the estimate: 65%); the middle value is on the limit's open side.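

No step between compound 1, compound 2 and compound 3 can be read in this assay, since each result is a limit and not a number: the limit of < 5000 nM in this assay, at which 3 of the 3 values shown sit.

The compounds shown leave open how soluble each one actually is, and whether changing the aromatic group on the shared core makes any difference.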